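Nitro to hydrogen on the aryl of the thiazolylidene series

This account rests on a few compounds, and the source may have more. Where it says the series, first, only, none or still open, it means among the compounds named here.

Measured so far in a functional assay on C6 cells (Rattus norvegicus) for cytotoxicity, read by MTT assay, with a stated time of 24 h; on this read-out higher numbers stand for weaker inhibition and lower numbers for stronger inhibition:
compound 1 `O=C(CSc1nnnn1-c1ccccc1)N/N=c1/scc(-c2ccccc2)n1-c1ccccc1`: 8.3 ug/mL
compound 2 `Cn1cnnc1SCC(=O)N/N=c1/scc(-c2ccc(Br)cc2)n1-c1ccccc1`: "not determined" (no result reported)
compound 3 `Cn1cnnc1SCC(=O)N/N=c1/scc(-c2ccc([N+](=O)[O-])cc2)n1-c1ccccc1`: "not determined" (no result reported)

Among the measured compounds shown here, compound 1 carries a phenyl on the shared core and gives 8.3 ug/mL in this assay, the only number in the set. Compound 2 has no result in this assay, its entry reads "not determined" (no result reported). Compound 3 likewise has no single number in this assay, its entry reads "not determined" (no result reported); it stands with one further entry of the same kind, so nothing can be said of where it sits against compound 1.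

The step goes from compound 3 to compound 4 `Cn1cnnc1SCC(=O)N/N=c1/scc(-c2ccccc2)n1-c1ccccc1`, which is yet to be measured in this assay. The change is hydrogen in place of nitro on an aromatic carbon. For the measured compounds named here, no step between measured compounds exists here to set a size or a direction for it; the expectation is that the step in this assay stays within the scatter, with no direction claimed.

Compound 4 is expected to give about 10 ug/mL in this assay, with a range from 3 ug/mL to 35 ug/mL, because compound 1 on the same phenyl gives 8.3 ug/mL and differs from compound 4 only in the heteroaryl thioether.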

Compound 4, half-maximal inhibitory concentration: 68.3 ug/mL
Compound 4: middle estimate off by 6.8-fold (0.83 log units), on the low side; measured number outside the range, above it.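

In this assay, among the compounds shown here, with phenyl held fixed on the shared core, 4-methyl-4H-1,2,4-triazol-3-yl in place of 1-phenyl-1H-tetrazol-5-yl on the sulfur gives an 8.2-fold higher number from compound 1 to compound 4 (0.92 log units; beyond the scatter) and makes the group on the sulfur the first change with a readable size and direction. Compound 4 gives the triazolyl thioether series its first number, on the hydrogen side of the nitro to hydrogen change, but the step from compound 3 to compound 4 cannot be read while compound 3 has no number, and compound 2 has no number either, so this position on the aryl remains without any measured effect. No supporting measurement is available to account for the step on the sulfur.

Open, as far as these compounds go, is whether 4-nitrophenyl to phenyl moves the number at all on this triazolyl thioether, and in which direction. Also open, from the compounds shown here alone, is what an amine or a carboxylic acid would do on that aromatic carbon, para to a large group, and what a longer chain in place of the methyl on the triazolyl group would do.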